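The compounds below may be only part of what the source reports. "The series", "measured", "known", "first", "only" and "open" are said of these compounds alone.

- compound 1 `CN1C/C(=C\c2ccc(F)cc2)C(=O)/C(=C/c2cccc([N+](=O)[O-])c2)C1`: 17600 nM
- compound 2 `CN1C/C(=C\c2cccc([N+](=O)[O-])c2)C(=O)/C(=C/c2ccc(Cl)cc2Cl)C1`: 14000 nM

Going by the values given here, these two values come from an ADME assay on L02 cells (Homo sapiens) for cytotoxicity, read by MTT assay, with a stated time of 24 h (a higher number here means a weaker inhibitor, a lower number a stronger inhibitor), and they leave compound 1 level with compound 2, the only other compound measured so far. The open question is compound 3 `CN1C/C(=C\c2ccc(C(F)(F)F)cc2)C(=O)/C(=C/c2cccc([N+](=O)[O-])c2)C1`, which differs from compound 1 by trifluoromethyl in place of fluoro on an aromatic carbon, with trifluoromethyl in place of fluoro on an aromatic carbon, para to a large group. Among the compounds with values here, one measured step bears on this, as it also replaces the 4-fluorophenyl of compound 1: a 1.3-fold lower number from compound 1 to compound 2 (0.10 log units; within the scatter). That single step is thin evidence, but it gives no reason to expect a shift beyond the scatter in this assay, and no direction can be drawn from it. The estimated change is a 1.2-fold lower number from compound 1 to compound 3 (0.07 log units; within the scatter). For compound 3 the expected value is 15000 nM, with an estimated range of 7000 nM to 30000 nM.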

Compound 3, half-maximal inhibitory concentration: 12400 nM
Beside the measured number, compound 3's estimate is 1.2-fold (0.08 log units) above it; the measured number falls inside the stated range.
By their numbers in this assay, from the lowest: compounds 3, 2 and 1 (each within the scatter of the next).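

Trifluoromethyl in place of fluoro, on an aromatic carbon para to a large group, gives in this assay a 1.4-fold lower number from compound 1 to compound 3 (0.15 log units; within the scatter). Unlike the earlier step, which exchanged the whole substituted phenyl group, this change alters one substituent at one position, and it shows that this position accepts a group of 4 heavy atoms in place of 1 with no shift beyond the scatter. Nothing measured here bears on why the numbers stay so close.

The compounds shown leave open whether an amine or a carboxylic acid at this same position would move the number beyond the scatter. All three compounds also keep their nitro group, so what a nitrile in its stead would do remains an open question.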